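The source may report more compounds than this note shows. Statements on the series, on what has been measured and on what is new or still open speak of the compounds shown alone.

Series notes, substituent on the pyridine-type ring of the shared core.

Going by the values given here, compound 3 `C[C@H](NC(=O)c1cc(C(F)(F)F)nn1C)c1nc(-c2ccnc(C3CC3)c2)no1` sits lowest of the three numbers so far: in an assay on T-REx-293 cells for inhibition of potassium channel subfamily T member 1 (Homo sapiens), read by patch clamp (on this read-out higher numbers stand for weaker inhibition and lower numbers for stronger inhibition), compound 3 gives 16 nM. Compound 2 `C[C@H](NC(=O)c1cc(C(F)(F)F)nn1C)c1nc(-c2ccnc(N3CCCC3)c2)no1` gives 573 nM in this assay, and compound 1 `C[C@H](NC(=O)c1cc(C(F)(F)F)nn1C)c1nc(-c2ccncc2)no1` gives 5250 nM. The two steps that reach compound 3 are both beyond the scatter: a 330-fold lower number from compound 1 to compound 3 (2.52 log units; beyond the scatter) and a 36-fold lower number from compound 2 to compound 3 (1.55 log units; beyond the scatter); the weaker change is a 9.2-fold lower number from compound 1 to compound 2 (0.96 log units; beyond the scatter).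

Compound 4 `COC(C)(C)c1cc(-c2noc([C@H](C)NC(=O)c3cc(C(F)(F)F)nn3C)n2)ccn1` is the next compound for this assay. The change from compound 3 is 1-methoxy-1-methylethyl in place of cyclopropyl on an aromatic carbon. Among the compounds with values here, no measured step replaces cyclopropyl by a non-ring, oxygen-containing substituent, so the measured steps bear only indirectly: both substituents tried at this position beat hydrogen, and cyclopropyl beat pyrrolidin-1-yl by a 36-fold lower number from compound 2 to compound 3 (1.55 log units; beyond the scatter). The expectation is therefore a moderately higher number than compound 3, well short of the gap back to compound 2, because a 330-fold lower number from compound 1 to compound 3 (2.52 log units; beyond the scatter) shows the position tolerates substitution strongly. Compound 4 is estimated at 80 nM, with a range of 25 nM to 300 nM, an expected step of a 5.0-fold higher number from compound 3 to compound 4 (0.70 log units; beyond the scatter).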

Compound 4, half-maximal inhibitory concentration: 6280 nM
The estimate for compound 4 lay 79-fold (1.89 log units) below the measured number; the whole stated range lies below it.
By their numbers in this assay, from the lowest: compound 3; then compound 2; then compounds 1 and 4 (each within the scatter of the next).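

The position does not reward every substituent: with 1-methoxy-1-methylethyl in place of hydrogen, this assay shows a 1.2-fold higher number from compound 1 to compound 4 (0.08 log units; within the scatter), so this group, unlike cyclopropyl and pyrrolidin-1-yl, brings no gain over hydrogen. Exchanging cyclopropyl for this group gives up the gain that cyclopropyl brought, with a 390-fold higher number from compound 3 to compound 4 (2.59 log units; beyond the scatter), and exchanging pyrrolidin-1-yl for it also gives a step upward, with an 11-fold higher number from compound 2 to compound 4 (1.04 log units; beyond the scatter). Nothing available gives a reason for these steps.

The compounds shown leave open whether the outcome turns on the three-membered ring of cyclopropyl or on the oxygen of 1-methoxy-1-methylethyl. An isopropyl chain, a cyclobutyl ring or a 1-methoxycyclopropyl group in the same place would separate the two.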